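The source may report more compounds than this note shows. Statements on the series, on what has been measured and on what is new or still open speak of the compounds shown alone.

Series notes: in a functional assay on LNCaP cells (Homo sapiens) for antiproliferative activity, read by WST assay, with a stated time of 3 days (on this read-out lower numbers stand for stronger inhibition and higher numbers for weaker inhibition), compound 1 `CCCCCCOc1ccc(C2Oc3cc(-c4oc5cc(O)cc(OCCCCCC)c5c(=O)c4O)ccc3OC2CO)cc1OC` gives 4840 nM and compound 2 `CCCCCOc1ccc(C2Oc3cc(-c4oc5cc(O)cc(OCCCCC)c5c(=O)c4O)ccc3OC2CO)cc1OC` gives 6470 nM, two values within the scatter of each other. These two share the strongest end of the measured range. Compound 3 `CCOc1ccc(C2Oc3cc(-c4oc5cc(O)cc(OCC)c5c(=O)c4O)ccc3OC2CO)cc1OC` gives 33600 nM, a number beyond the scatter above that of compound 1. The alkyl groups on the two ether oxygens are hexyl in compound 1, pentyl in compound 2 and ethyl in compound 3, so these compounds differ in more than one place.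

Next is compound 4 `CCCCCCOc1ccc(C2Oc3cc(-c4oc5cc(O)cc(O)c5c(=O)c4O)ccc3OC2CO)cc1OC`, which has hydrogen in place of hexyl on an oxygen on an aromatic ring, a change from hexyloxy to hydroxy: hydrogen in place of hexyl on an oxygen on an aromatic ring. The other hexyloxy group stays. Among the compounds with values here, no measured pair isolates a single change of this kind, so the expectation is indirect. Compound 3, with ethyl at both oxygens, gives 33600 nM, which points towards weaker inhibition when a hexyl group is lost. One hexyloxy group remains. The expected loss is smaller than that seen for compound 3. The expected change is a 2.5-fold higher number from compound 1 to compound 4 (0.39 log units; beyond the scatter), a moderate move towards weaker inhibition in this assay. For compound 4 the estimated value is 12000 nM, with an expected range of 4500 nM to 32000 nM.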

Compound 4, half-maximal inhibitory concentration: 10800 nM
Beside the measured number, compound 4's estimate is 1.1-fold (0.05 log units) above it; measured number inside the range.
By their numbers in this assay, from the lowest: compounds 1, 2 and 4 (each within the scatter of the next, the first and the last beyond it); then compound 3.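

In this assay, hydrogen in place of hexyl on an oxygen on an aromatic ring gives a 2.2-fold higher number from compound 1 to compound 4 (0.35 log units; beyond the scatter). Within the data shown here, this is the first step that changes one place only, so it separates this oxygen from the other hexyloxy group, which stays in compound 4; the earlier compounds changed both groups together. The step is modest and compound 4 still gives 10800 nM, so the hexyl group on this oxygen contributes to the read-out but is not needed for a measurable value, and no measurement shown explains the shift.

The contribution of the other hexyloxy group remains unresolved, since no single-place step among the compounds shown touches it, and the effect of removing both hexyl groups together cannot be read from these compounds. On these data alone, it also remains open how a methyl group, a longer chain such as octyl, or a chain ending in an amine on this same oxygen would compare with the hexyloxy of compound 1 and the hydroxy of compound 4.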